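Urea series: trifluoromethyl in place of methoxy

This account rests on a few compounds, and the source may have more. Where it says the series, first, only, none or still open, it means among the compounds named here.

Compound 1 `CC(C)c1cccc(C(C)C)c1NC(=O)NCC1(c2cccs2)CCCC1` gives 12 nM in an assay on microsomes from intestine for inhibition of acyl-CoA:cholesterol acyltransferase (Oryctolagus cuniculus); a higher number here means a weaker inhibitor, a lower number a stronger inhibitor.
Compound 2 `COc1ccccc1NC(=O)NCC1(c2ccccc2)CCCCC1` gives 270 nM in this assay.

Compound 2 shows the higher of the two numbers in this assay; compound 1 gives the lower number, and the gap between the two values lies beyond the scatter. Compound 3 `O=C(NCC1(c2ccccc2)CCCCC1)Nc1ccccc1C(F)(F)F` differs from compound 2 by trifluoromethyl in place of methoxy on an aromatic carbon. Within the data shown here, no pair of measured compounds isolates this change, so the expectation rests on the two values alone. A step of a 1.8-fold lower number from compound 2 to compound 3 (0.26 log units; within the scatter) is expected, toward a lower number, only a little beyond the scatter. Compound 3 is estimated at 150 nM in this assay, with a range from 50 nM to 450 nM.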

Compound 3, half-maximal inhibitory concentration: 200 nM
For compound 3 the middle estimate is 1.3-fold (0.12 log units) below the measured one; low and high end bracket the measured number.
By their numbers in this assay, from the lowest: compound 1; then compounds 3 and 2 (each within the scatter of the next).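

In this assay, among these compounds, a 1.4-fold lower number from compound 2 to compound 3 (0.13 log units; within the scatter) lies within the scatter, so this is the first pair to isolate a change at this place, and methoxy and trifluoromethyl on this aromatic carbon, ortho to a large group, cannot be told apart. Four heavy atoms without a hydrogen-bond acceptor thus stand in for two heavy atoms with one, with no change beyond the scatter. Nothing on hand gives a reason for this result. From the compounds shown here alone, whether an amine, a carboxylic acid or a longer chain on this carbon would move the number beyond the scatter stays open, as does whether trifluoromethyl in place of methoxy reads the same on other cores.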